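The source may report more compounds than this note shows. Statements on the series, on what has been measured and on what is new or still open speak of the compounds shown alone.

Measured so far in an ADME assay on BJ cells (Homo sapiens) for antiproliferative activity, with a stated time of 72 h; on this read-out lower numbers stand for an effect already at smaller amounts and higher numbers for an effect only at larger amounts of compound:
Compound 1 `COc1ccc(-c2cc(=O)c3c(OC)cc(OC)cc3n2S(=O)(=O)c2ccc([N+](=O)[O-])cc2)cc1`: > 29300 nM, a limit of the assay.
Compound 2 `COc1ccc(-c2cc(=O)c3c(OC)cc(OC)cc3n2S(=O)(=O)c2c(F)c(F)c(F)c(F)c2F)cc1`: > 34400 nM, a limit of the assay.
Compound 3 `COc1ccc(-c2cc(=O)c3c(OC)cc(OC)cc3n2S(=O)(=O)c2cccc(Br)c2)cc1`: > 58600 nM, a limit of the assay.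

Compound 3 thus stands at the limit of > 58600 nM in this assay, at which 1 of the 3 values shown sits, and its place among the others cannot be read, since the steps a step that the two limits leave unreadable from compound 1 to compound 3 and a step that the two limits leave unreadable from compound 2 to compound 3 run between limits. Compound 4 `COc1ccc(-c2cc(=O)c3c(OC)cc(OC)cc3n2S(=O)(=O)Cc2ccccc2)cc1` differs from compound 3 by benzyl in place of 3-bromophenyl on a sulfonyl sulfur. The measured steps that exchange the group on the sulfonyl sulfur, a step that the two limits leave unreadable from compound 1 to compound 2, a step that the two limits leave unreadable from compound 1 to compound 3 and a step that the two limits leave unreadable from compound 2 to compound 3, are all unreadable, so they give no size for this assay. Compound 4 is therefore expected to remain at a limit, with an estimated 60000 nM ranging from 20000 nM to 200000 nM. The step expected is a step that the limit leaves unreadable from compound 3 to compound 4, of no readable size.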

Compound 4, half-maximal effective concentration: > 34400 nM
Compound 4 ended at the assay's limit (the forecaster's own chance of this, stated with the estimate: 85%); the middle value does not contradict the limit.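

Among these compounds, compound 4 sits at a limit of the assay, as do compound 1, compound 2 and compound 3, so no step to compound 4 can be read in this assay. The compounds shown leave open whether any group on the sulfonyl sulfur gives a readable value.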